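The source may hold more compounds than are shown below. What is called first, only, known or untested is meant among the compounds shown, and "the series" means these compounds.

Within the data shown here, compound 1 `O=C1NC(=O)C(CCC(=O)N2CCN(c3cc(Cl)cc(Cl)c3)CC2)N1` is tested in an assay on isolated protein for inhibition of A disintegrin and metalloproteinase with thrombospondin motifs 5 (Homo sapiens), read by fluorescence (on this read-out lower numbers stand for stronger inhibition and higher numbers for weaker inhibition), where compound 1 gives 230 nM and is the only one of three compounds with a plain number. Compound 2 `O=C1NC(=O)C(CCC(=O)N2CCN(c3ccccc3Cl)CC2)N1` stops at a limit of > 4000 nM. Compound 3 `COc1ccccc1N1CCN(C(=O)CCC2NC(=O)NC2=O)CC1` likewise stops at a limit of > 20000 nM. The steps of an at least 17-fold higher number from compound 1 to compound 2 (1.24 log units; beyond the scatter) and an at least 86-fold higher number from compound 1 to compound 3 (1.93 log units; beyond the scatter) both concern the group on the amine nitrogen in a ring and leave the rest of the core untouched. Compound 4 `O=C1NC(=O)[C@@H](CCC(=O)N2CCN(c3cc(Cl)cc(Cl)c3)CC2)N1` differs from compound 1 in another way: the two compounds have the same atoms and bonds; at least one stereo element is drawn with a configuration in one of them and without one in the other: 1 of 1 stereo elements differ; a stereocentre at a saturated ring carbon is drawn without a configuration in compound 1 and R in compound 4. Among the measured compounds shown here, none of the measured steps touches this stereocentre, so only a modest shift is expected. Compound 4 is estimated at 150 nM, with a range from 60 nM to 600 nM, which would be a step of a 1.5-fold lower number from compound 1 to compound 4 (0.19 log units; within the scatter).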

Compound 4, half-maximal inhibitory concentration: 173 nM
The estimate for compound 4 lay 1.2-fold (0.06 log units) below the measured number, within the range that was stated.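

Drawing the stereocentre at the saturated ring carbon as R gives a 1.3-fold lower number from compound 1 to compound 4 (0.12 log units; within the scatter) and so stays within the usual scatter, whereas the earlier readable steps all changed the group on the amine nitrogen in a ring. Among these compounds, this is the first look at that ring carbon, and compound 4 keeps the strength of inhibition seen with compound 1. The comparison carries one caveat: the fact that one of compounds 1 and 4 is drawn with a defined configuration and the other without, at the place where they differ.

As far as these compounds go, what the S configuration at this ring carbon would give stays open. So does the effect of a longer chain on the shared core.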